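Methyl Ester to Dimethylamide on Two Different Cores

The compounds below may be only part of what the source reports. "The series", "measured", "known", "first", "only" and "open" are said of these compounds alone.

Compound 1 `COC(=O)c1oc2ccc(Nc3ncnc4ccc(Cl)nc34)cc2c1C` and compound 2 `COC(=O)c1cccc(C#Cc2ccccc2Nc2ncnc3ccc(Cl)nc23)c1` rest on different cores; the difference between the two cores is not broken down here. In an assay on isolated protein for inhibition of MAP kinase-interacting serine/threonine-protein kinase 2 (Homo sapiens), read by HTRF, in the presence of a further agent that is not named here (on this read-out lower numbers stand for stronger inhibition and higher numbers for weaker inhibition), compound 1 gives 4800 nM. In this assay compound 2 gives 4200 nM, a number that lies within the scatter of the number for compound 1. Compound 3 `CN(C)C(=O)c1cccc(C#Cc2ccccc2Nc2ncnc3ccc(Cl)nc23)c1` differs from compound 2 by one change, (dimethylamino in place of methoxy on a carbonyl carbon). In this assay compound 3 reaches only a limit of the assay, > 10000 nM. The measured step, an at least 2.3-fold higher number from compound 2 to compound 3 (0.37 log units; beyond the scatter), is accordingly known only as a bound, because one of the three values is the limit of > 10000 nM in this assay, at which 1 of the 3 values shown sits. Compound 4 `Cc1c(C(=O)N(C)C)oc2ccc(Nc3ncnc4ccc(Cl)nc34)cc12` carries the same change, made on the core of compound 1: dimethylamino in place of methoxy on a carbonyl carbon. Since the place of the change is the same in both pairs, the step from compound 1 to compound 4 in this assay is expected to be of a similar size, namely a 2.5-fold higher number from compound 1 to compound 4 (0.40 log units; beyond the scatter), resting on the measured at least 2.3-fold higher number from compound 2 to compound 3 (0.37 log units; beyond the scatter). Compound 4 is therefore estimated at 12000 nM, with a range from 6000 nM to 30000 nM, and the result may itself come back only as a limit.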

Compound 4, half-maximal inhibitory concentration: 2200 nM
Compound 4: the middle estimate sits 5.5-fold (0.74 log units) above what was measured, and the stated range ends above it.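

In this assay, the exchange of methoxy for dimethylamino on a carbonyl carbon gives a 2.2-fold lower number from compound 1 to compound 4 (0.34 log units; beyond the scatter), so the same change moves the number in opposite directions on the two cores: the same change on two cores in this assay, an at least 2.3-fold higher number (0.37 log units; beyond the scatter) from compound 2 to compound 3 and a 2.2-fold lower number (0.34 log units; beyond the scatter) from compound 1 to compound 4, at least 5.1-fold (0.71 log units) apart, beyond the scatter of two such steps

The direction of this change therefore did not carry from the core of compound 2 to the core of compound 1, and in this series the step on one core gave no reliable guide to the step on the other. Resting on one pair per core, this does not show why the two cores part, and the full size of the gap remains unknown, since compound 3 stands at a limit of the assay: the limit of > 10000 nM in this assay, at which 1 of the 4 values shown sits.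

The compounds shown leave open whether other groups on this carbonyl carbon, such as a simple amino group, a morpholine ring or a hydroxyl group giving the carboxylic acid, would follow the trend of compound 1 or that of compound 3. They also leave open whether a diethylamino group would behave as dimethylamino does on either core.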